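A few compounds are considered here, and "the series" means these few. Any claim that something is new, unique, unknown or untested is made for them only; others in the source may bear on it.

Of the compounds shown here, three have so far been tested in a functional assay on L02 cells (Homo sapiens) for inhibition, read by Griess assay, with stated times of 1 h and 24 h; on this read-out lower numbers stand for stronger inhibition and higher numbers for weaker inhibition. Compound 1 `CCCc1nn(C)c2c(NCc3ccc(F)cc3)nc(CCc3cccnc3)nc12` gives < 40000 nM, which is a limit of the assay rather than a number. Compound 2 `C(=C/c1ccco1)\c1nc(NC2CC2)c2sccc2n1` gives > 1000000 nM, also a limit. Compound 3 `CCN1CCN(c2nc(/C=C/c3cc(OC)c(OC)c(OC)c3)nc3ccsc23)CC1` gives > 1000000 nM, again a limit and not a measured number. Compound 3 therefore stands at the limit of > 1000000 nM in this assay, at which 2 of the 3 values shown sit, whereas compound 1 sits at the limit of < 40000 nM in this assay, at which 1 of the 3 values shown sits; with no real number among the three, no order between compound 2 and compound 3 can be read from these values.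

Compound 4 `COc1cc(/C=C/c2nc(NCc3ccc(C)cc3)c3sccc3n2)cc(OC)c1OC` is the next compound to be measured. It differs from compound 3 in a single place: (4-methylbenzyl)amino in place of 4-ethylpiperazin-1-yl on an aromatic carbon. The rest of the molecule is unchanged. For the measured compounds named here, no step between two measured compounds is available to guide the size of this change, since every value around it is a limit. Compound 2 shares the core of compound 3 and likewise sits at the limit. The step from compound 3 to compound 4 is expected to be an at least 1.6-fold lower number from compound 3 to compound 4 (0.22 log units; that floor lies within the scatter), leaning towards somewhat stronger inhibition but with great uncertainty. Compound 4 is estimated at 600000 nM, within a range from 50000 nM to 2000000 nM, with a fair chance that only a limit is reported.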

Compound 4, half-maximal inhibitory concentration: > 1000000 nM
Compound 4 ended at the assay's limit (the forecaster's own chance of this, stated with the estimate: 60%); middle value at least 1.6-fold (0.22 log units) from the limit.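

In this assay compound 4 gives > 1000000 nM, which is a limit of the assay and not a number. For the compounds shown here, compound 3 gives > 1000000 nM, also a limit, so no step between these two compounds can be read. The compounds shown leave open whether (4-methylbenzyl)amino in place of 4-ethylpiperazin-1-yl changes inhibition at all.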